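The source may report more compounds than this note shows. Statements on the series, on what has been measured and on what is new or still open speak of the compounds shown alone.

Three analogues of one shared core have numbers in an assay on CHO cells for displacement of a labelled ligand from prostaglandin E2 receptor EP3 subtype (Homo sapiens), read by radioligand binding; a higher number here means a weaker inhibitor, a lower number a stronger inhibitor. Compound 1 `CC(C)C(Nc1nnc[nH]1)c1ccc(-c2ccc3cccc(F)c3c2)[nH]c1=O` gives 22 nM. Compound 2 `Cc1nc(C(c2ccc(-c3ccc4cccc(F)c4c3)[nH]c2=O)C(C)C)[nH]c1C` gives 7 nM. Compound 3 `CC(C)C(c1nnc[nH]1)c1ccc(-c2ccc3cccc(F)c3c2)[nH]c1=O` gives 12 nM, the second highest of the three; the nearest neighbour is compound 2, with a 1.7-fold higher number from compound 2 to compound 3 (0.23 log units; within the scatter), and the furthest is compound 1, with a 1.8-fold lower number from compound 1 to compound 3 (0.26 log units; within the scatter), so compound 3 is parted from neither by more than the scatter. Among the compounds with values here, the only step in the set that passes the scatter is a 3.1-fold lower number from compound 1 to compound 2 (0.50 log units; beyond the scatter).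

Compound 4 `CC(C)C(Nc1nccs1)c1ccc(-c2ccc3cccc(F)c3c2)[nH]c1=O` is the next member: (1,3-thiazol-2-yl)amino in place of 4H-1,2,4-triazol-3-yl on a saturated chain carbon bound to an aromatic carbon and a saturated chain carbon. The change has two parts. The amino link that enters is the one removed in a 1.8-fold lower number from compound 1 to compound 3 (0.26 log units; within the scatter), a step that stayed within the scatter. Within the data shown here, the exchange of the 4H-1,2,4-triazol-3-yl ring for a 1,3-thiazol-2-yl ring has no measured counterpart here; the one ring swap on record, a 3.1-fold lower number from compound 1 to compound 2 (0.50 log units; beyond the scatter), shows that such a swap can move the number beyond the scatter. For compound 4 the expected step in this assay is therefore a 1.3-fold higher number from compound 3 to compound 4 (0.10 log units; within the scatter), with the range kept wide for the untested ring. Compound 4 is expected to give 15 nM, between 5 nM and 45 nM.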

Compound 4, inhibition constant: 9.4 nM
Compound 4: the middle estimate sits 1.6-fold (0.20 log units) above what was measured; the range from low to high includes it.
By their numbers in this assay, from the lowest: compounds 2, 4, 3 and 1 (each within the scatter of the next, the first and the last beyond it).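

In this assay, (1,3-thiazol-2-yl)amino on a saturated chain carbon bound to an aromatic carbon and a saturated chain carbon stays level with both groups that lack the amino link: the record shows a 1.3-fold lower number from compound 3 to compound 4 (0.11 log units; within the scatter) and a 1.3-fold higher number from compound 2 to compound 4 (0.13 log units; within the scatter) so compound 4 cannot be separated from compound 2 or compound 3 at this position. Within the data shown here, with the amino link held constant, the ring alone can be read for the first time, and the exchange on the amine nitrogen gives a 2.3-fold lower number from compound 1 to compound 4 (0.37 log units; beyond the scatter) which is a modest step but does pass the scatter, so the identity of the ring on that link registers in this assay even though removing the link from compound 1 did not. No measurement here accounts for this difference between the two rings.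

The series leaves open what 1,3-thiazol-2-yl would give when bound directly to the saturated chain carbon, which would show the amino link's contribution with this ring rather than with 4H-1,2,4-triazol-3-yl. Also open, from the compounds shown here alone, is how a phenyl ring or a carboxylic acid at the same place would compare with compound 4 in this assay and whether this position tolerates groups without a five-membered aromatic ring.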